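This account rests on a few compounds, and the source may have more. Where it says the series, first, only, none or still open, it means among the compounds named here.

Values measured so far in a functional assay on SK-N-FI cells (Homo sapiens) for cytotoxicity, with a stated time of 5 days (on this read-out higher numbers stand for weaker inhibition and lower numbers for stronger inhibition), are these.
- compound 1 `COc1cc(OC)c(C(C#CCCc2ccc(O[Si](C)(C)C(C)(C)C)cc2)CC(=O)c2ccc(O)cc2)c(OC)c1` gives 31100 nM in this read-out
- compound 2 `COc1cc(OC)c(C(C#CCCc2ccc(O[Si](C)(C)C(C)(C)C)cc2)CC(=O)c2ccc(OC(C)=O)cc2)c(OC)c1` gives 22100 nM in this read-out

Within the data shown here, compound 2 lies within the scatter of compound 1, the only other measured compound, so it holds no separate place on these numbers. The next compound is compound 3 `COc1cc(OC)c(C(C#CCCc2ccc(O[Si](C)(C)C(C)(C)C)cc2)CC(=O)c2ccc(O[Si](C)(C)C(C)(C)C)cc2)c(OC)c1` and the structural change is a group of 7 heavy atoms (6 carbon, 1 silicon; no ring) in place of a group of 3 heavy atoms (2 carbon, 1 oxygen; no ring), on an oxygen on an aromatic ring on an oxygen on an aromatic ring. Among the measured compounds shown here, one measured step bears on this oxygen, and it is a 1.4-fold lower number from compound 1 to compound 2 (0.15 log units; within the scatter) with acetyl in place of hydrogen. That step lies within the scatter. For the measured compounds named here, it is the sole guide here, and the larger group entering has no measured precedent at this oxygen. No step beyond the scatter is therefore expected in this assay in either direction. The estimated step is a 1.1-fold higher number from compound 2 to compound 3 (0.05 log units; within the scatter) in this expectation. The expected value for compound 3 is 25000 nM within an estimated range of 10000 nM to 60000 nM on present evidence.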

Compound 3, half-maximal inhibitory concentration: > 100000 nM
Compound 3: no number, only a limit (the forecaster's own chance of this, stated with the estimate: 15%); middle value at least 4.0-fold (0.60 log units) away from the limit.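

This oxygen on an aromatic ring is no longer silent in this assay: acetyl in place of hydrogen gave no step beyond the scatter, whereas the group of 7 heavy atoms (6 carbon, 1 silicon) gives an at least 4.5-fold higher number from compound 2 to compound 3 (0.65 log units; beyond the scatter) and, measured against the hydrogen, an at least 3.2-fold higher number from compound 1 to compound 3 (0.50 log units; beyond the scatter). Compound 3 gives > 100000 nM, which is a limit of the assay and not a number, so the full size of both steps cannot be read: the limit of > 100000 nM in this assay, at which 1 of the 3 values shown sits. Hydrogen and acetyl read alike at this oxygen, and so far only the larger group separates from them.

On these data alone, how a longer alkyl chain or a chain ending in an amine would read at this oxygen stays open. The change therefore cannot yet be tied to the silicon or to the heavy-atom count alone.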